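Urea aryl variation on the thiophene sulfonamide series

The source may hold more compounds than are shown below. What is called first, only, known or untested is meant among the compounds shown, and "the series" means these compounds.

Measured so far:
compound 1 `COc1ccc(NC(=S)NCCNS(=O)(=O)c2sccc2-c2ccc(C)cc2Oc2ccc(O)c(O)c2)cc1` — > 20000 nM
compound 2 `Cc1ccc(-c2ccsc2S(=O)(=O)NCCNC(=O)Nc2cccc([N+](=O)[O-])c2)c(Oc2ccc(O)c(O)c2)c1` — > 20000 nM
compound 3 `Cc1ccc(-c2ccsc2S(=O)(=O)NCCNC(=O)Nc2ccc([N+](=O)[O-])cc2)c(Oc2ccc(O)c(O)c2)c1` — > 20000 nM

In a functional assay on HeLa cells (Homo sapiens) for inhibition, read by CCK-8 assay, with a stated time of 48 h (on this read-out lower numbers stand for stronger inhibition and higher numbers for weaker inhibition), compound 3 gives only a limit, > 20000 nM, and no number. Among the compounds with values here, the same holds for every value so far (the limit of > 20000 nM in this assay, at which 3 of the 3 values shown sit). Accordingly the steps a step that the two limits leave unreadable from compound 1 to compound 3 and a step that the two limits leave unreadable from compound 2 to compound 3 cannot be read for size or direction, and the only step on the amide-type nitrogen, a step that the two limits leave unreadable from compound 2 to compound 3, gives no guidance either.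

Compound 4 `Cc1ccc(-c2ccsc2S(=O)(=O)NCCNC(=O)Nc2cc(Cl)cc(Cl)c2)c(Oc2ccc(O)c(O)c2)c1` is the next change at that position: 3,5-dichlorophenyl in place of 4-nitrophenyl on an amide-type nitrogen. Within the data shown here, no measured step bears readably on it, so no step beyond the scatter can be predicted in either direction. Compound 4 is therefore expected to remain near the limit, at about 20000 nM, between 6000 nM and 60000 nM. The implied step from compound 3 to compound 4, a number no higher from compound 3 to compound 4 (the limit leaves the size open), is expected to be nil.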

Compound 4, half-maximal inhibitory concentration: 6500 nM
Beside the measured number, compound 4's estimate is 3.1-fold (0.49 log units) above it; the measured number falls inside the stated range.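

On the amide-type nitrogen, the series now gives a readable change: 3,5-dichlorophenyl in place of 4-nitrophenyl gives an at least 3.0-fold lower number from compound 3 to compound 4 (0.48 log units; beyond the scatter) in this assay. In place of 3-nitrophenyl it gives an at least 3.0-fold lower number from compound 2 to compound 4 (0.48 log units; beyond the scatter), and the larger change on the amine nitrogen gives an at least 3.0-fold lower number from compound 1 to compound 4 (0.48 log units; beyond the scatter). Each step is open-ended, and the remaining compounds sit at a limit: the limit of > 20000 nM in this assay, at which 3 of the 4 values shown sit.

Going by these compounds, the steps among compound 1, compound 2 and compound 3 cannot be read, so any effect of moving the nitro group remains unknown. Also open, on these data alone, is how a cyclohexyl group or a pyridine ring on this nitrogen would compare with 3,5-dichlorophenyl.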